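Cyclopentyloxy for cyclopentylamino on a shared core

The source may report more compounds than this note shows. Statements on the series, on what has been measured and on what is new or still open speak of the compounds shown alone.

In a physicochemical assay for solubility (on this read-out lower numbers stand for lower solubility and higher numbers for higher solubility), compound 1 `C[C@@H]1CN(c2cc(C(F)(F)F)nn2-c2ccc(S(C)(=O)=O)cn2)[C@H](C)CO1` gives 100 ug/mL as its result, while compound 3 `CS(=O)(=O)c1ccc(-n2nc(C(F)(F)F)cc2NC2CCCC2)nc1` gives 25 ug/mL and holds the lower of the two numbers. Compound 2 `CS(=O)(=O)c1ccc(-n2nc(C(F)(F)F)cc2NCC2CC2)nc1` stands as "not determined" (no result reported) and adds no number. Compound 4 `CS(=O)(=O)c1ccc(-n2nc(C(F)(F)F)cc2OC2CCCC2)nc1` has not yet been measured. Its difference from compound 3 is cyclopentyloxy in place of cyclopentylamino on an aromatic carbon and amounts to cyclopentyloxy in place of cyclopentylamino on an aromatic carbon.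

Among the compounds with values here, only one measured step is available, a 4.0-fold lower number from compound 1 to compound 3 (0.60 log units; beyond the scatter) and it exchanged a different pair of groups, so it bears on this change only loosely. Within the data shown here, no measured pair compares cyclopentyloxy with cyclopentylamino directly. Its size therefore offers no firm guide, and only a small downward move within the scatter is expected. Compound 3 at 25 ug/mL serves as the anchor for this expectation. The expected step is a 1.4-fold lower number from compound 3 to compound 4 (0.14 log units; within the scatter) and remains an estimate. Compound 4 is estimated at 18 ug/mL in this assay with an expected range from 6 ug/mL to 45 ug/mL for the measurement.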

Compound 4, solubility: 50 ug/mL
Estimate against measurement, compound 4: 2.8-fold (0.44 log units) below; measured number outside the range, above it.
By their numbers in this assay, from the lowest: compounds 3, 4 and 1 (each within the scatter of the next, the first and the last beyond it).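

At this position, on an aromatic carbon of the shared core, cyclopentyloxy in place of cyclopentylamino takes the group from 1 hydrogen-bond donor to 0 with the five-membered ring kept, and it comes to (a 2.0-fold higher number from compound 3 to compound 4 (0.30 log units; within the scatter)), so this assay does not separate these two groups. The larger group of compound 1 gives way to cyclopentyloxy with (a 2.0-fold lower number from compound 1 to compound 4 (0.30 log units; within the scatter)), whereas (a 4.0-fold lower number from compound 1 to compound 3 (0.60 log units; beyond the scatter)) lies beyond the scatter, so only the cyclopentylamino group stands clearly apart from that larger group. Nothing at hand accounts for any of these steps.

Compound 2 has no number, so the open-chain amine it carries says nothing here. From the compounds shown here alone, how a longer alkoxy chain or a carboxylic acid at this position would read in this assay remains open.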